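The source may hold more compounds than are shown below. What is called first, only, known or untested is meant among the compounds shown, and "the series" means these compounds.

In a functional assay on HepG2 cells (Homo sapiens) for cytotoxicity, read by MTT assay, with a stated time of 72 h (a higher number here means a weaker inhibitor, a lower number a stronger inhibitor), compound 1 (`Cc1c(C)c2c(c(C)c1OC(=O)CCC(=O)O)CCC(C)(C(=O)NC1CC(C)(C)N([O])C(C)(C)C1)O2`) gives > 300000 nM, which is a limit of the assay and not a number. Compound 2 (`Cc1c(C)c2c(c(C)c1OC(=O)CCC(=O)O)CCC(C)(C(=O)NCC1CC(C)(C)N([O])C1(C)C)O2`) gives > 300000 nM, which is also only a limit. Among the measured compounds shown here, the one measured step, a step that the two limits leave unreadable from compound 1 to compound 2, therefore has no readable size. Compound 3 (`Cc1c(C)c2c(c(C)c1OC(=O)CCC(=O)NCC1CC(C)(C)N([O])C1(C)C)CCC(C)(C(=O)NCC1CC(C)(C)N([O])C1(C)C)O2`) differs from compound 2 in one place: a group of 12 heavy atoms (9 carbon, 2 nitrogen, 1 oxygen; one five-membered non-aromatic ring with 1 hetero atom) in place of one oxygen atom, on a carbonyl carbon. In words, a group of 12 heavy atoms with one five-membered non-aromatic ring takes the place of the hydroxy on a carbonyl carbon. For the measured compounds named here, no measured step covers this kind of change, so the data give neither a size nor a direction for it in this assay. Going by the values given here, the only guide is the limit of > 300000 nM in this assay, at which 2 of the 2 values shown sit, and a result near that limit is expected. For compound 3, the estimate is 250000 nM, with an expected range of 80000 nM to 800000 nM. This estimate corresponds to an expected at least 1.2-fold lower number from compound 2 to compound 3 (0.07 log units; that floor lies within the scatter), which remains uncertain.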

Compound 3, half-maximal inhibitory concentration: 176000 nM
For compound 3 the middle estimate is 1.4-fold (0.15 log units) above the measured one; measured number inside the range.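

In this assay, among the compounds shown here, compound 3 gives 176000 nM, the only value shown that is a number. The other two values are limits and not numbers, and the step between them cannot be read: the limit of > 300000 nM in this assay, at which 2 of the 3 values shown sit.

Putting the group of 12 heavy atoms with its five-membered non-aromatic ring on the carbonyl carbon, in place of the hydroxy, gives an at least 1.7-fold lower number from compound 2 to compound 3 (0.23 log units; that floor lies within the scatter), so this position can carry a much larger group and still give a readable value, although the size of the step is known only as a floor.

Going by these compounds, it stays open how a methyl ester or a simple amine would read on this carbonyl carbon. Also open, on these data alone, is how a group with a six-membered non-aromatic ring would read in the same place.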